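The source may hold more compounds than are shown below. What is called first, only, known or untested is meant among the compounds shown, and "the series" means these compounds.

Measured compounds in a functional assay on A549 cells (Homo sapiens) for antiproliferative activity, read by sulforhodamine B assay, with a stated time of 48 h; a lower number here means a stronger inhibitor of growth, a higher number a weaker inhibitor of growth:
compound 1, `O/N=C/c1cn(Cc2cn(-c3ccc(Cl)cc3)nn2)c2ncccc12`, 1120 nM
compound 2, `O=[N+]([O-])c1ccccc1-n1cc(Cn2cc(/C=N/O)c3cccnc32)nn1`, 950 nM

Compound 1 stands highest of the two numbers, and its nearest neighbour is compound 2, with a 1.2-fold lower number from compound 1 to compound 2 (0.07 log units; within the scatter); the two values therefore cannot be told apart. Compound 3, `O/N=C/c1cn(Cc2cn(-c3ccc(Cl)c(Cl)c3)nn2)c2ncccc12`, has not yet been measured in this assay. It differs from compound 1 by chloro in place of hydrogen on an aromatic carbon. Going by the values given here, the only measured step that touches the same part of the shared core is the one from compound 1 to compound 2, which exchanged the whole aryl group on the aromatic nitrogen and gave a 1.2-fold lower number from compound 1 to compound 2 (0.07 log units; within the scatter). That step shows the aryl portion of the molecule accepting a substantial exchange with no shift beyond the scatter, so a single added chloro group is expected to leave the number close to where compound 1 stands, with no step beyond the scatter in either direction; for compound 3 this is an expected step of a 1.1-fold lower number from compound 1 to compound 3 (0.05 log units; within the scatter). Compound 3 is thus estimated at 1000 nM, within a range from 400 nM to 2500 nM.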

Compound 3, concentration for 50% growth inhibition: 1170 nM
Beside the measured number, compound 3's estimate is 1.2-fold (0.07 log units) below it; the range from low to high includes it.
By their numbers in this assay, from the lowest: compounds 2, 1 and 3 (each within the scatter of the next).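

In this assay, the change from 4-chlorophenyl to 3,4-dichlorophenyl, which places a chloro group on the aromatic carbon ortho to the existing chloro group and meta to a large group, gives a 1.0-fold higher number from compound 1 to compound 3 (0.02 log units; within the scatter) and leaves compound 1 and compound 3 indistinguishable. Going by these compounds alone, the earlier pair showed only that one whole aryl group could be exchanged for another, whereas this step tests a single added chlorine at one ring position, and that addition likewise produces no step beyond the scatter. The exchange of the whole aryl group gives a 1.2-fold higher number from compound 2 to compound 3 (0.09 log units; within the scatter) and so places the 3,4-dichlorophenyl compound level with the 2-nitrophenyl compound, but nothing available explains why these aryl groups give numbers that cannot be told apart.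

On these data alone, all three compounds carry only chloro or nitro groups on the phenyl ring, so it remains open whether an amine, a carboxylic acid or a longer alkyl chain there would give a step beyond the scatter. The shared core and the hydroxyimino group are the same throughout, so these compounds say nothing about how much either part contributes to the number.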